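Para substituent on the benzyl arm of compound 2

This account rests on a few compounds, and the source may have more. Where it says the series, first, only, none or still open, it means among the compounds named here.

Compound 1 `O=C(CCC1C(=O)N(c2ccc(Cl)cc2)C(=O)N1Cc1ccc(Br)cc1)Nc1ccc(C(=O)NO)cc1` and compound 2 `Cc1ccc(CN2C(=O)N(c3ccc(Cl)cc3)C(=O)C2CCC(=O)Nc2ccc(C(=O)NO)cc2)cc1` share one core and differ only on the benzyl arm. In an assay on isolated protein for inhibition of polyamine deacetylase HDAC10 (Homo sapiens), read by fluorescence, with stated times of 5 min and 60 min (a higher number here means a weaker inhibitor, a lower number a stronger inhibitor), compound 1 gives 268 nM, and in this assay compound 2 gives 164 nM; the step of a 1.6-fold lower number from compound 1 to compound 2 (0.21 log units; within the scatter) stays within the scatter, so the two numbers cannot be ordered, and compound 2 simply stands at the lower of the two numbers shown, a difference within the scatter. Compound 3 `O=C(CCC1C(=O)N(c2ccc(Cl)cc2)C(=O)N1Cc1ccccc1)Nc1ccc(C(=O)NO)cc1` is the next step: hydrogen in place of methyl on an aromatic carbon. For the measured compounds named here, only one measured step bears on this carbon, the one from compound 1 to compound 2, and it stayed within the scatter, so a hydrogen there is expected to read much alike. The step of a 1.4-fold higher number from compound 2 to compound 3 (0.15 log units; within the scatter) is therefore expected to be none beyond the scatter, if anything a slightly higher number. Compound 3 is estimated at 230 nM, with a range from 110 nM to 500 nM.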

Compound 3, half-maximal inhibitory concentration: 114 nM
Compound 3: the middle estimate sits 2.0-fold (0.30 log units) above what was measured, and the stated range covers the measured number.
By their numbers in this assay, from the lowest: compounds 3, 2 and 1 (each within the scatter of the next, the first and the last beyond it).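

In this assay hydrogen in place of methyl gives a 1.4-fold lower number from compound 2 to compound 3 (0.16 log units; within the scatter), so hydrogen and methyl cannot be told apart on this aromatic carbon, para to a large group. Hydrogen in place of bromo gives a 2.4-fold lower number from compound 1 to compound 3 (0.37 log units; beyond the scatter), the first step at this position to pass beyond the scatter, though only modestly, while compound 2 lies within the scatter of both compound 1 and compound 3. Nothing at hand explains the difference between bromo and hydrogen here.

The compounds shown leave open whether an amine, a carboxylic acid or a methoxy group on this carbon would shift the number further than bromo does. They also leave open whether a longer chain in place of the methyl would stay within the scatter of compound 2.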